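Methyl on the chain carbon bound to the amide nitrogen

The source may hold more compounds than are shown below. What is called first, only, known or untested is meant among the compounds shown, and "the series" means these compounds.

Compound 1 `COc1ccc(C(=C/C=C/C(=O)NCCCCc2cccnc2)c2ccc(OC)c(OC)c2)cc1OC` and compound 3 `COc1ccc(C(=C/C=C/C(=O)N[C@H](C)CCCc2cccnc2)c2ccc(OC)c(OC)c2)cc1OC` share one core; in an assay (Canis lupus familiaris) for binding affinity to platelet-activating factor receptor (Homo sapiens), read by radioligand binding (a higher number here means a weaker inhibitor, a lower number a stronger inhibitor), compound 1 gives 55 nM and compound 3 gives 50 nM. The change between them, (methyl in place of hydrogen on a saturated chain carbon bound to an amide-type nitrogen and a saturated chain carbon), moves the number by a 1.1-fold lower number from compound 1 to compound 3 (0.04 log units; within the scatter). Compound 2 `O=C(/C=C/C=C(c1cccc(F)c1)c1cccc(F)c1)NCCCCc1cccnc1` carries a different core; the difference between the two cores is not broken down here. In this assay compound 2 gives 20 nM, the lowest of the three numbers, beyond the scatter from both compound 1 and compound 3. Compound 4 `C[C@H](CCCc1cccnc1)NC(=O)/C=C/C=C(c1cccc(F)c1)c1cccc(F)c1` is not yet measured. It differs from compound 2 by methyl in place of hydrogen on a saturated chain carbon bound to an amide-type nitrogen and a saturated chain carbon, the same change as from compound 1 to compound 3, at a place described in the same words. The expected step from compound 2 to compound 4 in this assay is a 1.1-fold lower number from compound 2 to compound 4 (0.05 log units; within the scatter), close to the earlier one, because the measured step of a 1.1-fold lower number from compound 1 to compound 3 (0.04 log units; within the scatter) lay within the scatter; whether this carries over to the core of compound 2 is not shown by any other pair. Compound 4 is therefore estimated at 18 nM, with a range from 9 nM to 36 nM expected.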

Compound 4, half-maximal inhibitory concentration: 170 nM
Compound 4: the middle estimate sits 9.4-fold (0.98 log units) below what was measured; the measured number lies above the stated range.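

On the core of compound 2, methyl in place of hydrogen on a saturated chain carbon bound to an amide-type nitrogen and a saturated chain carbon gives an 8.5-fold higher number from compound 2 to compound 4 (0.93 log units; beyond the scatter) in this assay, whereas on the core of compound 1 the same change gives a 1.1-fold lower number from compound 1 to compound 3 (0.04 log units; within the scatter). The outcome of this change therefore depends on the core, and a step read on one core in this series cannot simply be carried to the other: the same change on two cores in this assay, a 1.1-fold lower number (0.04 log units; within the scatter) from compound 1 to compound 3 and an 8.5-fold higher number (0.93 log units; beyond the scatter) from compound 2 to compound 4, 9.4-fold (0.97 log units) apart, beyond the scatter of two such steps. Which feature of the two cores sets this difference is not shown, and the finding rests on only one pair for each core.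

Open, on these data alone, is whether ethyl in place of the methyl on the same chain carbon, or the opposite configuration at that carbon, would follow the same split between the two cores. Also open, as far as these compounds go, is whether chlorine in place of fluorine on the core of compound 2 would keep the same rise in the number when the methyl is present.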